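This account rests on a few compounds, and the source may have more. Where it says the series, first, only, none or still open, it means among the compounds named here.

Compound 1, `COc1ccc(CN2C(=O)C(=O)c3cc(-c4ccc(O)cc4)ccc32)cc1`, compound 2, `COc1ccc(CN2C(=O)C(O)c3cc(-c4ccc(OC)cc4)ccc32)cc1`, and compound 3, `COC(=O)/C=C1\C(=O)N(Cc2ccc(OC)cc2)c2ccc(-c3ccc(OC)cc3)cc21`, share one core and have all been run in a functional assay on HepG2 cells (Homo sapiens) for antiproliferative activity, read by MTT assay, with a stated time of 48 h; a higher number here means a weaker inhibitor, a lower number a stronger inhibitor. For compound 1 the result is only a limit, > 10000 nM, and not a number. Compound 2 gives 700 nM in this assay, while compound 3 gives 4730 nM. Among the two numbers shown, compound 3 stands highest, with compound 2 the nearest to it and lying below it by a gap beyond the usual scatter; the third value is a limit of > 10000 nM in this assay, at which 1 of the 3 values shown sits, and says nothing about order.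

Compound 4, `COc1ccc(CN2C(=O)/C(=C\c3ccc(C(C)C)cc3)c3cc(-c4ccc(OC)cc4)ccc32)cc1`, has not yet been measured in this assay. It differs from compound 3 in one place: 4-isopropylphenyl in place of methoxycarbonyl on a double-bonded chain carbon bound to a double-bonded ring carbon, in words 4-isopropylphenyl in place of methoxycarbonyl on a double-bonded chain carbon bound to a double-bonded ring carbon. For the measured compounds named here, no measured pair in this set makes the same change, so there is no step to lean on. Given that compound 2, which lacks the exocyclic double bond, gives 700 nM, a move toward the lower end seems plausible but is uncertain, and the step from compound 3 to compound 4 is estimated as a 3.2-fold lower number from compound 3 to compound 4 (0.50 log units; beyond the scatter). For compound 4 the expected value in this assay is therefore 1500 nM, with a range from 300 nM to 8000 nM.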

Compound 4, half-maximal inhibitory concentration: > 10000 nM
Compound 4 gave a limit, no number; the forecaster's own chance of this, stated with the estimate: 10%; middle value at least 6.6-fold (0.82 log units) away from the limit.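

In this assay, for the compounds shown here, putting 4-isopropylphenyl in place of methoxycarbonyl on a double-bonded chain carbon bound to a double-bonded ring carbon gives an at least 2.1-fold higher number from compound 3 to compound 4 (0.32 log units; beyond the scatter), which shows that the group at this place matters for the read-out, something the earlier compounds could not show because no measured pair differed here alone. Compound 4 gives > 10000 nM, a limit of the assay and not a number, so the step has a lower bound only and its full size cannot be read. The result also adds to the values that cannot be placed in order: the limit of > 10000 nM in this assay, at which 2 of the 4 values shown sit.

The change removes methoxycarbonyl and brings in an all-carbon aromatic ring in one move, so the compounds shown do not separate the loss of the one from the arrival of the other. On these data alone, whether a carboxylic acid, an amine or a plain phenyl at this place would keep the value of compound 3, lower it or raise it to the limit remains open.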